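This account rests on a few compounds, and the source may have more. Where it says the series, first, only, none or still open, it means among the compounds named here.

Compounds measured so far:
- compound 1 `Cn1c(=O)c(=O)n(C2CCCC2)c2nc(N/N=C/c3ccccc3)ncc21`: 48200 nM
- compound 2 `Cn1c(=O)c(=O)n(C2CCCC2)c2nc(N/N=C/c3ccc(S(C)(=O)=O)cc3)ncc21`: 26600 nM
- compound 3 `Cn1c(=O)c(=O)n(C2CCCC2)c2nc(N/N=C/c3ccc(O)c(F)c3)ncc21`: 85200 nM

In a functional assay on PC-3 cells (Homo sapiens) for antiproliferative activity, read by MTT assay (on this read-out lower numbers stand for stronger inhibition and higher numbers for weaker inhibition), compound 3 gives the highest of the three numbers. Its nearest neighbour is compound 1, a 1.8-fold higher number from compound 1 to compound 3 (0.25 log units; within the scatter), and its furthest is compound 2, a 3.2-fold higher number from compound 2 to compound 3 (0.51 log units; beyond the scatter). Compound 4 `Cn1c(=O)c(=O)n(C2CCCC2)c2nc(N/N=C/c3cccc(Cl)c3Cl)ncc21` differs from compound 3 by 2,3-dichlorophenyl in place of 3-fluoro-4-hydroxyphenyl on a carbon with a double bond to nitrogen. Among the measured compounds shown here, no measured step touches a chlorinated phenyl, so the bearing steps are only those just named, one within the scatter and one modest. Removing the hydroxy and fluorine of compound 3 is therefore expected to move the number back toward that of compound 1, giving an estimated step of a 1.7-fold lower number from compound 3 to compound 4 (0.23 log units; within the scatter). Compound 4 is expected at 50000 nM, within 15000 nM to 160000 nM.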

Compound 4, half-maximal inhibitory concentration: 17200 nM
The estimate for compound 4 lay 2.9-fold (0.46 log units) above the measured number; the range from low to high includes it.
By their numbers in this assay, from the lowest: compounds 4, 2, 1 and 3 (each within the scatter of the next, the first and the last beyond it).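

In this assay, a change at this position now gives a step beyond the scatter from the plain phenyl, a 2.8-fold lower number from compound 1 to compound 4 (0.45 log units; beyond the scatter), which neither earlier substituted ring did. Exchanging the 3-fluoro-4-hydroxyphenyl gives a 5.0-fold lower number from compound 3 to compound 4 (0.69 log units; beyond the scatter), whereas exchanging the 4-(methylsulfonyl)phenyl gives only a 1.5-fold lower number from compound 2 to compound 4 (0.19 log units; within the scatter). No evidence at hand bears on these steps. The compounds shown do not tell whether both chlorines are needed, as no ring with a single chlorine appears among them. Going by these compounds, how an amine or a carboxylic acid on this phenyl would compare also stays open.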